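This account rests on a few compounds, and the source may have more. Where it says the series, first, only, none or still open, it means among the compounds named here.

Compound 1 (`COc1ccc2c(/C=C(\C#N)C(=O)c3c[nH]c4cc(OC)ccc34)c[nH]c2c1`) reads > 50000 nM in a functional assay on MIA PaCa-2 cells (Homo sapiens) for cytotoxicity, read by WST assay, with a stated time of 24 h (a lower number here means a stronger inhibitor, a higher number a weaker inhibitor), which is a limit and not a number. Compound 2 (`N#C/C(=C\c1c[nH]c2cc(F)ccc12)C(=O)c1c[nH]c2cc(F)ccc12`) reads > 50000 nM, also a limit. For the measured compounds named here, compound 3 (`N#C/C(=C\c1cn(Cc2ccc(Cl)cc2)c2ccc(Br)cc12)C(=O)c1c[nH]c2ccccc12`) gives 37700 nM, the one true number so far. Compound 1 therefore stands at the limit of > 50000 nM in this assay, at which 2 of the 3 values shown sit. Compound 4 (`COc1ccc2c(/C=C(\C#N)C(=O)c3c[nH]c4ccccc34)c[nH]c2c1`) has hydrogen in place of methoxy on an aromatic carbon of compound 1: hydrogen in place of methoxy on an aromatic carbon. Going by the values given here, no measured pair isolates this change, so the expectation rests on the values alone. The expected a number no higher from compound 1 to compound 4 (the limit leaves the size open) is none beyond the scatter, with no direction favoured. For compound 4 the estimate is 50000 nM, with an expected range of 22000 nM to 110000 nM.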

Compound 4, half-maximal inhibitory concentration: 27500 nM
Estimate against measurement, compound 4: 1.8-fold (0.26 log units) above, within the range that was stated.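

Hydrogen in place of methoxy on this aromatic carbon gives the first pair in the series that differs in one place, and it shows an at least 1.8-fold lower number from compound 1 to compound 4 (0.25 log units; that floor lies within the scatter). In this assay compound 4 gives 27500 nM, a true number. Compound 1 reads as a limit, so the step is a floor and not a size: the limit of > 50000 nM in this assay, at which 2 of the 4 values shown sit.

From the compounds shown here alone, the true size of the step stays open. So does whether an amine or a longer alkoxy chain such as ethoxy on this carbon would read differently from hydrogen.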